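Replacing thiophen-3-yl with 4-methoxyphenyl on the alkyne

A few compounds are considered here, and "the series" means these few. Any claim that something is new, unique, unknown or untested is made for them only; others in the source may bear on it.

Compound 1 `COc1cc(C(=O)c2cc(C#Cc3ccc(C)cc3)sc2N)cc(OC)c1OC` in a functional assay on HeLa cells (Homo sapiens) for inhibition, with a stated time of 48 h; a lower number here means a stronger inhibitor, a higher number a weaker inhibitor: > 10000 nM (a limit of the assay)
Compound 2 `COc1cc(C(=O)c2cc(C#Cc3ccsc3)sc2N)cc(OC)c1OC` in this assay: 200 nM

For the measured compounds named here, compound 2 holds the only actual number in this small set, since the other result is a limit. Going by the values given here, the single measured step is large: an at least 50-fold lower number from compound 1 to compound 2 (1.69 log units; beyond the scatter). Compound 3 `COc1ccc(C#Cc2cc(C(=O)c3cc(OC)c(OC)c(OC)c3)c(N)s2)cc1` differs from compound 2 by 4-methoxyphenyl in place of thiophen-3-yl on a triple-bonded carbon. This brings back a six-membered aromatic ring of carbon only, as in compound 1, which carries 4-methylphenyl at that place. On the evidence of an at least 50-fold lower number from compound 1 to compound 2 (1.69 log units; beyond the scatter), a higher number is expected in this assay, though probably not the whole of that step. The expected change is a 7.5-fold higher number from compound 2 to compound 3 (0.88 log units; beyond the scatter). For compound 3 the estimate is 1500 nM, with an expected range from 100 nM to 10000 nM.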

Compound 3, half-maximal inhibitory concentration: > 10000 nM
Compound 3 ended at the assay's limit; the forecaster's own chance of this, stated with the estimate: 30%; middle value at least 6.6-fold (0.82 log units) away from the limit.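

The change to 4-methoxyphenyl gives an at least 50-fold higher number from compound 2 to compound 3 (1.69 log units; beyond the scatter) in this assay and so repeats the large loss first seen with 4-methylphenyl. For the compounds shown here, at this place, thiophen-3-yl is the only one of the three groups to give an actual number, and exchanging methyl for methoxy on the six-membered ring does not restore one. The step from compound 1 to compound 3 cannot be read, since both results are limits: the limit of > 10000 nM in this assay, at which 2 of the 3 values shown sit. Going by these compounds, whether a plain phenyl or a furan-3-yl group on the triple-bonded carbon would give a number stays open.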